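Amide variation on the shared core: an anilide replaces allyl(methyl)amino

The source may report more compounds than this note shows. Statements on the series, on what has been measured and on what is new or still open speak of the compounds shown alone.

For the measured compounds named here, compound 2 `C=CCN(C)C(=O)c1ccc(C(CC)(CC)c2ccc(OCC(O)C(C)(C)C)c(C)c2)n1CC` gives 3950 nM in an assay on HL-60 cells for agonist activity at vitamin D3 receptor (Homo sapiens), read by microscopy, with a stated time of 96 h (a higher number here means that more compound is needed for the effect, a lower number that less compound is needed), the highest of the two numbers so far; compound 1 `CCn1c(C(=O)NCC(OC)OC)ccc1C(CC)(CC)c1ccc(OCC(O)C(C)(C)C)c(C)c1` gives 150 nM. Going by the values given here, the single measured step, a 26-fold higher number from compound 1 to compound 2 (1.42 log units; beyond the scatter), shows that a change at the carbonyl carbon can move this assay a long way. Compound 3 `CCn1c(C(=O)Nc2cccc(C(F)(F)F)c2)ccc1C(CC)(CC)c1ccc(OCC(O)C(C)(C)C)c(C)c1` has (3-(trifluoromethyl)phenyl)amino in place of allyl(methyl)amino on a carbonyl carbon. Among the compounds with values here, no measured step covers this group; the one step in hand bears only by analogy, and a return toward the number of compound 1 is expected rather than a further rise. Compound 3 is estimated at 400 nM, range 80 nM to 2000 nM. This expectation corresponds to a 9.9-fold lower number from compound 2 to compound 3 (0.99 log units; beyond the scatter).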

Compound 3, half-maximal effective concentration: > 50000 nM
Compound 3: a limit, no number (the forecaster's own chance of this, stated with the estimate: 5%); at least 120-fold (2.09 log units) between middle value and limit.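

In this assay compound 3 gives a limit and not a number: the limit of > 50000 nM in this assay, at which 1 of the 3 values shown sits.

On the carbonyl carbon, (3-(trifluoromethyl)phenyl)amino gives an at least 12-fold higher number from compound 2 to compound 3 (1.10 log units; beyond the scatter), so this position can move the number further than the earlier step showed. Compound 1 and compound 3 both keep the amide hydrogen, yet the change on the amide-type nitrogen gives an at least 330-fold higher number from compound 1 to compound 3 (2.52 log units; beyond the scatter), so that hydrogen alone does not hold the number low.

Open, going by these compounds, is whether the aromatic ring or the trifluoromethyl group accounts for the step. A plain phenylamino group would separate the two.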